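The source may report more compounds than this note shows. Statements on the series, on what has been measured and on what is new or still open speak of the compounds shown alone.

Measured compounds:
compound 1 `CCOC(=O)N1CCC(Oc2ncnc3c2CCN3c2ccc(S(C)(=O)=O)cc2F)CC1` gives 251 nM
compound 2 `CCS(=O)(=O)N1CCC(Oc2ncnc3c2CCN3c2ccc(S(C)(=O)=O)cc2F)CC1` gives 1580 nM

Both numbers come from a functional assay on CHO-K1 cells for agonist activity at Glucose-dependent insulinotropic receptor (Homo sapiens), read by a luciferase reporter, with a stated time of 5 h; a lower number here means that less compound is needed, a higher number that more compound is needed for the effect. Within the data shown here, compound 1 stands lowest of the two, and the only other compound, compound 2, sits a 6.3-fold higher number from compound 1 to compound 2 (0.80 log units; beyond the scatter) away; that step swapped the group on the ring nitrogen and shows that this position matters to the read-out.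

The untested compound 3 `CC(C)c1noc(N2CCC(Oc3ncnc4c3CCN4c3ccc(S(C)(=O)=O)cc3F)CC2)n1` changes the same position once more: 3-isopropyl-1,2,4-oxadiazol-5-yl in place of ethoxycarbonyl on an amine nitrogen in a ring. The new group is larger than the one it replaces and brings one more hydrogen-bond acceptor, and it is an aromatic ring where the old group was an open chain. Among the measured compounds shown here, the single relevant comparison, the step from compound 1 to compound 2, showed that a change here can shift the number beyond the scatter, but it involved a different entering group, so it cannot say in which direction compound 3 will move. For the measured compounds named here, with no closer precedent, the most defensible expectation for compound 3 in this assay is a number near that of compound 1, with the step of a 1.6-fold lower number from compound 1 to compound 3 (0.20 log units; within the scatter) expected to stay within the scatter or lean slightly lower. Compound 3 is therefore estimated at 160 nM, within a range from 40 nM to 650 nM.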

Compound 3, half-maximal effective concentration: 79.4 nM
Beside the measured number, compound 3's estimate is 2.0-fold (0.30 log units) above it; the measured number falls inside the stated range.
By their numbers in this assay, from the lowest: compound 3; then compound 1; then compound 2.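

In this assay, among these compounds, the earlier pair showed only that a change on this ring nitrogen can raise the number, whereas 3-isopropyl-1,2,4-oxadiazol-5-yl shows that a change here can also lower it, with a 3.2-fold lower number from compound 1 to compound 3 (0.50 log units; beyond the scatter). Measured against the sulfonyl group, the same ring gives a 20-fold lower number from compound 2 to compound 3 (1.30 log units; beyond the scatter), so the choice of group at this one position spans a wide range of numbers. The position therefore takes a group with one five-membered aromatic ring and 8 heavy atoms in place of the open-chain ethoxycarbonyl with 5, and the number still falls; no measurement offered here explains why.

Only one ring-bearing group appears at this nitrogen, so the compounds shown cannot separate what the aromatic ring contributes from what its isopropyl group contributes. The same ring carrying a methyl or a tert-butyl group in place of isopropyl would address that question, while a pyrimidine ring on the nitrogen would test whether the 1,2,4-oxadiazole ring itself is needed.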